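A few compounds are considered here, and "the series" means these few. Any claim that something is new, unique, unknown or untested is made for them only; others in the source may bear on it.

Measured in a functional assay on G-361 cells (Homo sapiens) for antiproliferative activity, with a stated time of 72 h; on this read-out lower numbers stand for stronger inhibition and higher numbers for weaker inhibition:
- compound 1 `OC[C@H]1O[C@@H](n2cnc3c(NCc4cccc(F)c4)ncnc32)[C@H](O)[C@@H]1O`: > 166000 nM
- compound 2 `Cc1cccc(CNc2ncnc3c2ncn3[C@@H]2O[C@H](CO)[C@@H](O)[C@H]2O)c1`: > 166000 nM
- compound 3 `OC[C@H]1O[C@@H](n2cnc3c(NCc4cccc(O)c4O)ncnc32)[C@H](O)[C@@H]1O`: 16900 nM

The entries for compound 1 and compound 2 are limits, not numbers: both sit at the limit of > 166000 nM in this assay, at which 2 of the 3 values shown sit. Compound 3 is the only one of the three with a number, 16900 nM.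

Next in the series is compound 4 `Cc1ccc(O)c(CNc2ncnc3c2ncn3[C@@H]2O[C@H](CO)[C@@H](O)[C@H]2O)c1`, with this change: 2-hydroxy-5-methylphenyl in place of 2,3-dihydroxyphenyl on a saturated chain carbon bound to a nitrogen on an aromatic ring. The 2-hydroxy-5-methylphenyl group keeps a hydroxy group, which the groups in compound 1 and compound 2 lack, but it also carries the methyl found in compound 2.

For the measured compounds named here, two measured steps bear on this: an at least 9.8-fold lower number from compound 1 to compound 3 (0.99 log units; beyond the scatter) and an at least 9.8-fold lower number from compound 2 to compound 3 (0.99 log units; beyond the scatter). Both are bounded by a limit at one end, so their true size is open. The third, a step that the two limits leave unreadable from compound 1 to compound 2, gives no size.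

Compound 4 is therefore expected to land between these measured results, with weaker inhibition in this assay. The estimated step is a 3.3-fold higher number from compound 3 to compound 4 (0.51 log units; beyond the scatter). A limit rather than a number would not be a surprise. For compound 4 the estimate is 55000 nM, with an expected range of 14000 nM to 166000 nM.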

Compound 4, half-maximal inhibitory concentration: > 166000 nM
Compound 4 was reported as a limit; the forecaster's own chance of this, stated with the estimate: 45%; at least 3.0-fold (0.47 log units) between middle value and limit.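

The entry for compound 4 is a limit, not a number. A single hydroxy group on the ring is therefore not enough at this position: 2-hydroxy-5-methylphenyl in place of 2,3-dihydroxyphenyl gives an at least 9.8-fold higher number from compound 3 to compound 4 (0.99 log units; beyond the scatter), and among the groups shown only 2,3-dihydroxyphenyl yields a number. The steps from compound 1 and from compound 2 to compound 4 cannot be read, so adding a hydroxy group to compound 2 shows no readable gain, as both ends sit at the same limit: the limit of > 166000 nM in this assay, at which 3 of the 4 values shown sit.

The change from compound 3 to compound 4 removes a hydroxy group and adds a methyl, and these two parts are not separated by the compounds shown. As far as these compounds go, it also remains open whether the 2-hydroxy-5-methylphenyl group without its methyl, or an amine or a methoxy group in place of one hydroxy group of 2,3-dihydroxyphenyl, would give a number.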